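The source may report more compounds than this note shows. Statements on the series, on what has been measured and on what is new or still open speak of the compounds shown alone.

Compound 1 `COC(=O)c1cccc(-c2cnc(C(=O)CCc3ccc(OC4CCN(C(=O)OC(C)(C)C)CC4)cc3)o2)n1` gives 32 nM in an assay for inhibition of Fatty-acid amide hydrolase 1 (Rattus norvegicus); on this read-out higher numbers stand for weaker inhibition and lower numbers for stronger inhibition; compound 2 `O=C(O)c1cccc(-c2cnc(C(=O)CCc3ccc(-c4ccc(CN5CCCCC5)cc4)cc3)o2)n1` gives 44 nM; compound 3 `COC(=O)c1cccc(-c2cnc(C(=O)CCc3ccc(-c4ccc(CN5CCCCC5)cc4)cc3)o2)n1` gives 9 nM.

Compound 3 and compound 2 share a core and differ only by hydrogen in place of methyl on an oxygen next to a carbonyl group, a change that produced a 4.9-fold higher number from compound 3 to compound 2 (0.69 log units; beyond the scatter). Compound 4 `CC(C)(C)OC(=O)N1CCC(Oc2ccc(CCC(=O)c3ncc(-c4cccc(C(=O)O)n4)o3)cc2)CC1` has not been measured; it carries the same change relative to compound 1, namely (hydrogen in place of methyl on an oxygen next to a carbonyl group), on the same kind of oxygen. How the core of compound 1 differs from that of compound 3 is not broken down here. Among the measured compounds shown here, since the single prior example of this change gave a 4.9-fold higher number from compound 3 to compound 2 (0.69 log units; beyond the scatter), compound 4 is expected to show a 4.1-fold higher number from compound 1 to compound 4 (0.61 log units; beyond the scatter), a step of similar size, though resting on one pair alone. Compound 4 is therefore estimated at 130 nM, with a range from 50 nM to 400 nM.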

Compound 4, inhibition constant: 120 nM
Compound 4: middle estimate off by 1.1-fold (0.03 log units), on the high side, and the stated range covers the measured number.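

Swapping methoxycarbonyl for carboxy on the core of compound 1 gave a 3.8-fold higher number from compound 1 to compound 4 (0.57 log units; beyond the scatter) in this assay. Set beside the earlier case, the change carried over from one core to the other with much the same size: the same change on two cores in this assay, a 4.9-fold higher number (0.69 log units; beyond the scatter) from compound 3 to compound 2 and a 3.8-fold higher number (0.57 log units; beyond the scatter) from compound 1 to compound 4, 1.3-fold (0.12 log units) apart, within the scatter of two such steps. Among the compounds shown here, these are only two cores, however, so this does not show that the step would hold on every core, and it does not explain why the number rises.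

The compounds shown leave open how an ethyl ester or a primary amide would read in place of the methoxycarbonyl. They also do not show whether either group would stay closer to the methyl ester or to the carboxylic acid.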